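The compounds below may be only part of what the source reports. "The series", "measured", "known", "first", "only" and "open" are said of these compounds alone.

Working notes on the series. The shared core carries an arylidene hydrazone at one position, and three variants of the aryl group have been measured in a functional assay on PC-3 cells (Homo sapiens) for antiproliferative activity, read by MTT assay; a higher number here means a weaker inhibitor, a lower number a stronger inhibitor. Compound 1 `COc1cccc(/C=N/Nc2ncc3c(n2)n(C2CCCC2)c(=O)c(=O)n3C)c1` gives 20700 nM. Compound 3 `COc1ccc(/C=N/Nc2ncc3c(n2)n(C2CCCC2)c(=O)c(=O)n3C)cc1` gives 26300 nM, a step of a 1.3-fold higher number from compound 1 to compound 3 (0.10 log units; within the scatter). Compound 2 `COc1ccc(/C=N/Nc2ncc3c(n2)n(C2CCCC2)c(=O)c(=O)n3C)c(OC)c1` reaches only the limit of the assay, > 100000 nM, which is the limit of > 100000 nM in this assay, at which 1 of the 3 values shown sits. Against it, the step of an at least 4.8-fold higher number from compound 1 to compound 2 (0.68 log units; beyond the scatter) and the step of an at least 3.8-fold lower number from compound 2 to compound 3 (0.58 log units; beyond the scatter) are both beyond the scatter. Among the two numbers shown, compound 1 stands lowest, with compound 3 within the scatter of it.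

Compound 4 `Cn1c(=O)c(=O)n(C2CCCC2)c2nc(N/N=C/c3ccc(F)cc3F)ncc21` is not yet measured. It differs from compound 1 by 2,4-difluorophenyl in place of 3-methoxyphenyl on a carbon with a double bond to nitrogen. Going by the values given here, no measured step swaps a methoxy for a fluorine, so the bearing of the measured steps is indirect: the 2,4-dimethoxyphenyl compound 2 sat at the limit, and the two methoxyphenyl isomers, compound 1 and compound 3, lie within the scatter of each other. In this assay compound 4 is therefore expected to give a number somewhat higher than compound 1, a step of a 1.7-fold higher number from compound 1 to compound 4 (0.23 log units; within the scatter), with some chance of a limit only. The estimate for compound 4 is 35000 nM, within a range from 12000 nM to 100000 nM.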

Compound 4, half-maximal inhibitory concentration: 13200 nM
Estimate against measurement, compound 4: 2.7-fold (0.42 log units) above; the measured number falls inside the stated range.
By their numbers in this assay, from the lowest: compounds 4, 1 and 3 (each within the scatter of the next). At a limit, above all of these: compound 2.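

In this assay, a 2,4-difluorophenyl on a carbon with a double bond to nitrogen reads level with both methoxyphenyl isomers, the steps being a 1.6-fold lower number from compound 1 to compound 4 (0.20 log units; within the scatter) and a 2.0-fold lower number from compound 3 to compound 4 (0.30 log units; within the scatter). The earlier compounds shown here offered only the 2,4-dimethoxyphenyl as a group with two substituents on the phenyl, and the new comparison, an at least 7.5-fold lower number from compound 2 to compound 4 (0.87 log units; beyond the scatter), shows that the weak reading of compound 2 does not follow from the arrangement it shares with the 2,4-difluorophenyl as such, but goes with the methoxy groups in that arrangement. Going by these compounds alone, compound 2 remains the only compound at a limit of the assay: the limit of > 100000 nM in this assay, at which 1 of the 4 values shown sits.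

Open, on these data alone, is whether a phenyl with no substituent, a monofluorophenyl or a phenyl with a single chlorine would read with compound 4 and the methoxyphenyl isomers, and which of the two methoxy groups of compound 2 goes with its limit. Also open, as far as these compounds go, is how a phenyl carrying an amine or a carboxylic acid, or a pyridine ring in place of the phenyl, would read at this position.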